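Methyl position on the pendant phenyl of the pyridine-linked series

The source may report more compounds than this note shows. Statements on the series, on what has been measured and on what is new or still open speak of the compounds shown alone.

For the measured compounds named here, compound 2 `Cc1ccccc1-c1cc(-c2ccoc2)cc(-c2ccc(Cl)s2)n1` stands at the lower of the two numbers so far in an assay on isolated protein for inhibition of DNA topoisomerase 1 (Homo sapiens), with a stated time of 30 min, tested at 100 uM (a higher number here means more inhibition at the concentration tested (going by the name of the read-out), a lower number less inhibition), where compound 2 gives 4.6%. Compound 1 `Cc1ccc(-c2cc(-c3ccoc3)cc(-c3ccc(Cl)s3)n2)o1` gives 13.2% in this assay, and the step of a number 8.6 percentage points lower from compound 1 to compound 2 (within the scatter) falls within the scatter, so the two measured compounds cannot be told apart. Compound 3 `Cc1cccc(-c2cc(-c3ccoc3)cc(-c3ccc(Cl)s3)n2)c1` differs from compound 2 by 3-methylphenyl in place of 2-methylphenyl on an aromatic carbon. Going by the values given here, no measured step moves the methyl group around the phenyl ring; the only step on record, a number 8.6 percentage points lower from compound 1 to compound 2 (within the scatter), swaps the whole aromatic group and stays within the scatter. On that basis no shift beyond the scatter is expected for a number 2.4 percentage points higher from compound 2 to compound 3 (within the scatter), and compound 3 is estimated to give 7% in this assay, with a range of -5% to 20%.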

Compound 3, a percentage reported as inhibition, at one concentration (the size of the read-out at that concentration, not a potency): 2.6%
Compound 3: middle estimate off by 4.4 percentage points, on the high side; low and high end bracket the measured number.
By their numbers in this assay, from the lowest: compounds 3, 2 and 1 (each within the scatter of the next, the first and the last beyond it).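

Moving the methyl from 2-methylphenyl to 3-methylphenyl, next to the ring nitrogen, gives a number 2 percentage points lower from compound 2 to compound 3 (within the scatter) in this assay, so this read-out does not separate the two methyl positions. For the compounds shown here, replacing 5-methylfuran-2-yl with 3-methylphenyl gives a number 10.6 percentage points lower from compound 1 to compound 3 (beyond the scatter), the first step to pass the scatter, though only modestly, while the matching change to 2-methylphenyl gives a number 8.6 percentage points lower from compound 1 to compound 2 (within the scatter). Nothing available explains this small difference between the two steps.

Still open, going by these compounds, is whether the methyl on the phenyl ring can be exchanged for an amine or a carboxylic acid with any rise in the number at this position. Also open, on these data alone, is whether 4-methylphenyl would fall with compound 2 and compound 3 or move beyond the scatter from them.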